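Changing the amine group on a chloropyrimidine core

The source may hold more compounds than are shown below. What is called first, only, known or untested is meant among the compounds shown, and "the series" means these compounds.

Compound 1 `Cc1ccccc1Nc1nc(NCc2ccco2)ncc1Cl` and compound 2 `CN1CCN(c2ccc(Nc3ncc(Cl)c(NCc4ccc(F)cc4)n3)nc2)CC1` share a chloropyrimidine core and were tested in a functional assay on MDA-MB-231 cells (Homo sapiens) for inhibition, read by CCK-8 assay, with a stated time of 48 h; on this read-out lower numbers stand for stronger inhibition of growth and higher numbers for weaker inhibition of growth. In this assay compound 1 gives only a limit, > 100000 nM, not a number. In this assay compound 2 likewise reaches only a limit, > 100000 nM. Going by the values given here, both values thus sit at the same boundary, (the limit of > 100000 nM in this assay, at which 2 of the 2 values shown sit), so compound 2 stands at the weak end of what this assay can report, and no step between measured compounds is available. Compound 3 `COc1cccc(Nc2nc(Nc3ccc(N4CCN(C)CC4)cn3)ncc2Cl)c1` differs from compound 2 in one place: 3-methoxyphenyl in place of 4-fluorobenzyl on a nitrogen on an aromatic ring. Among the compounds with values here, with no measured step to lean on, the expected change is uncertain; the step from compound 2 to compound 3 is estimated as an at least 3.3-fold lower number from compound 2 to compound 3 (0.52 log units; beyond the scatter) in this assay, toward stronger inhibition. Compound 3 is therefore expected to give about 30000 nM in this assay, with a range from 5000 nM to 200000 nM.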

Compound 3, concentration for 50% growth inhibition: 8510 nM
Beside the measured number, compound 3's estimate is 3.5-fold (0.55 log units) above it, within the range that was stated.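

On the nitrogen on an aromatic ring, 3-methoxyphenyl in place of 4-fluorobenzyl gives an at least 11-fold lower number from compound 2 to compound 3 (1.07 log units; beyond the scatter) in this assay. Compound 3 therefore provides the first real number among the compounds shown, and it reveals what the two earlier limits could not: changing this one group can move a compound off the weak boundary of the read-out. The true size of the step stays unknown, since the value of compound 2 is a limit and not a number: the limit of > 100000 nM in this assay, at which 2 of the 3 values shown sit.

The change replaces (4-fluorobenzyl)amino with (3-methoxyphenyl)amino, so the compounds shown cannot say whether the step comes from the methoxy group, the loss of the fluorine or the loss of the benzyl carbon. A 3-methoxybenzyl or an unsubstituted phenyl group at this place would help to separate these possibilities.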